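Sulfonamide nitrogen substituent on the shared core

This account rests on a few compounds, and the source may have more. Where it says the series, first, only, none or still open, it means among the compounds named here.

Going by the values given here, in an assay for inhibition of 6-phosphofructo-2-kinase/fructose-2,6-bisphosphatase 3 (Homo sapiens), read by ADP-Glo, with a stated time of 2 h (a lower number here means a stronger inhibitor, a higher number a weaker inhibitor), compound 2 `Cn1ccc2ccc(-c3cc(Nc4ccccc4S(=O)(=O)Nc4cncnc4)cc4nccnc34)cc21` gives 1690 nM, the higher of the two numbers so far, while compound 1 `CN(C)S(=O)(=O)c1ccccc1Nc1cc(-c2ccc3ccn(C)c3c2)c2nccnc2c1` gives 94 nM. Among the compounds with values here, the single measured step, an 18-fold higher number from compound 1 to compound 2 (1.25 log units; beyond the scatter), placed (pyrimidin-5-yl)amino where dimethylamino had been on the sulfonyl sulfur. Compound 3 `Cn1ccc2ccc(-c3cc(Nc4ccccc4S(=O)(=O)N4CCOCC4)cc4nccnc34)cc21` runs that change the other way: morpholin-4-yl in place of (pyrimidin-5-yl)amino on a sulfonyl sulfur. Within the data shown here, only this step bears on the move, and it was large, so a fall in this assay back toward the number of compound 1 is expected. Compound 3 is estimated at 150 nM, in the range 50 nM to 600 nM, which means an expected 11-fold lower number from compound 2 to compound 3 (1.05 log units; beyond the scatter).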

Compound 3, half-maximal inhibitory concentration: 36 nM
Compound 3: the middle estimate sits 4.2-fold (0.62 log units) above what was measured; the whole stated range lies above it.
By their numbers in this assay, from the lowest: compound 3; then compound 1; then compound 2.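

In this assay, a ring on the sulfonyl sulfur does not by itself give a high number: the non-aromatic morpholin-4-yl gives a 47-fold lower number from compound 2 to compound 3 (1.67 log units; beyond the scatter), in contrast to (pyrimidin-5-yl)amino. Morpholin-4-yl also improves on dimethylamino, with a 2.6-fold lower number from compound 1 to compound 3 (0.42 log units; beyond the scatter), so this position can go lower than compound 1. No measurement on hand accounts for either step.

As far as these compounds go, it remains open whether the morpholine oxygen matters, which piperidin-1-yl would test against compound 3. From the compounds shown here alone, whether the amide hydrogen of compound 2 or its pyrimidine ring drives its high number also remains open; N-methyl-N-(pyrimidin-5-yl)amino would help separate them.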